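The source may hold more compounds than are shown below. What is called first, only, known or untested is meant among the compounds shown, and "the series" means these compounds.

Working notes on the series. Three analogues carry the shared core: compound 1 `COc1ccc(-c2cc(/C=C/C(=O)c3ccc(OC)c(OC)c3)[nH]n2)cc1`, compound 2 `COc1cc(-c2cc(/C=C/C(=O)c3ccc(Cl)c(Cl)c3)[nH]n2)cc(OC)c1OC` and compound 3 `COc1ccc(-c2cc(/C=C/C(=O)c3cc(OC)c(OC)c(OC)c3)[nH]n2)cc1OC`. In a functional assay on SK-MEL-5 cells (Homo sapiens) for cytotoxicity, read by sulforhodamine B assay, with a stated time of 48 h, tested at 1 uM (on this read-out higher numbers stand for a weaker effect at the one concentration tested and lower numbers for a stronger effect), compound 1 gives 88%, compound 2 gives 94% and compound 3 gives 87%. The three numbers lie within the usual scatter of one another, so compound 2 is not separated from compound 1 or compound 3 on this read-out. Compound 4 `COc1ccc(C(=O)/C=C/c2cc(-c3cc(OC)c(OC)c(OC)c3)n[nH]2)cc1OC` is not yet measured. It differs from compound 2 by 3,4-dimethoxyphenyl in place of 3,4-dichlorophenyl on a carbonyl carbon. Since compound 1 and compound 3 already carry methoxy-bearing rings on the carbonyl carbon and sit with compound 2 in this assay, no step beyond the scatter is expected in either direction. For compound 4 the expected value in this assay is 89%, within 78% to 98%, which amounts to an expected step of a number 5 percentage points lower from compound 2 to compound 4 (within the scatter).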

Compound 4, a percentage reported as activity, at one concentration (the size of the read-out at that concentration, not a potency): 91%
Compound 4: middle estimate off by 2 percentage points, on the low side; the range from low to high includes it.
By their numbers in this assay, from the lowest: compounds 3, 1, 4 and 2 (each within the scatter of the next).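

The exchange of 3,4-dichlorophenyl for 3,4-dimethoxyphenyl on a carbonyl carbon amounts to a number 3 percentage points lower from compound 2 to compound 4 (within the scatter) in this assay. Unlike the earlier compounds, which differ in more than one place, this pair isolates that position, and at the one concentration tested the two groups are not separated. No measurement shown explains this result. Going by these compounds, whether an amine or a carboxylic acid on the carbonyl carbon would give a step beyond the scatter remains open. Also open, on these data alone, is whether these two groups would separate at other concentrations.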